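The compounds below may be only part of what the source reports. "The series", "measured", "known", "first", "only" and "open" are said of these compounds alone.

Compound 1, `O=C(COc1cccc2ccccc12)N/N=C/c1cccc(O)c1`, in an ADME assay on MT4 cells (Homo sapiens) for cytotoxicity, read by MTT assay, with a stated time of 4 days (a lower number here means that less compound is tolerated, a higher number that more compound is tolerated), gives 32.6 ug/mL.
Compound 2, `O=C(COc1cccc2ccccc12)N/N=C/c1ccccc1Br`, in this assay gives 11.4 ug/mL.
Compound 3, `O=C(COc1cccc2ccccc12)N/N=C/c1cccc([N+](=O)[O-])c1`, in this assay gives 12.1 ug/mL.

Among these three, compound 3 stands second highest in this assay: compound 2 sits within the usual scatter of it, while compound 1 sits clearly higher. Compound 4, `O=C(COc1cccc2ccccc12)N/N=C/c1cccc(Br)c1`, is not yet measured; it differs from compound 3 in one place: bromo in place of nitro on an aromatic carbon. Going by the values given here, two measured steps bear on this change. a 2.7-fold lower number from compound 1 to compound 3 (0.43 log units; beyond the scatter) brought the nitro group in, and a 2.9-fold lower number from compound 1 to compound 2 (0.46 log units; beyond the scatter) brought a bromo group in, though there as 2-bromophenyl in place of 3-hydroxyphenyl. Neither step sets bromo against nitro on the same aromatic carbon, but compound 2 and compound 3 give numbers within the scatter of each other, so a bromo group and a nitro group have so far gone together with a similar tolerated concentration. The step expected from this change is therefore a 1.1-fold lower number from compound 3 to compound 4 (0.04 log units; within the scatter), which means none beyond the scatter. On that basis compound 4 is estimated at 11 ug/mL in this assay, with a range from 5.5 ug/mL to 22 ug/mL.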

Compound 4, half-maximal cytotoxic concentration: 87.4 ug/mL
Compound 4: the middle estimate sits 7.9-fold (0.90 log units) below what was measured, outside the stated range (above it).
By their numbers in this assay, from the lowest: compounds 2 and 3 (each within the scatter of the next); then compound 1; then compound 4.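

In this assay, bromo and nitro on the same aromatic carbon do not behave alike, with a 7.2-fold higher number from compound 3 to compound 4 (0.86 log units; beyond the scatter) for that single swap, so the similar numbers of compound 2 and compound 3 did not carry over to this position. Where the bromo sits also counts: 3-bromophenyl in place of 2-bromophenyl gives a 7.7-fold higher number from compound 2 to compound 4 (0.88 log units; beyond the scatter) and bromo in place of hydroxy gives a 2.7-fold higher number from compound 1 to compound 4 (0.43 log units; beyond the scatter) on the same carbon, which leaves compound 4 as the most tolerated of the four, while the other two groups at this position, hydroxy and nitro, stay lower. Going by these compounds alone, nothing available here explains why this one change moves the number so far.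

On these data alone, it remains open whether the high tolerated concentration belongs to bromo itself or would also appear with a chlorine atom, a methyl group or an amine on the same aromatic carbon. Within the data shown here, with only three groups compared at this position, and a single bromo compound at each of two places, no general rule for the ring can yet be drawn.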